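From Dimethylamino to Cyclopentylamino at the Cytotoxicity Limit

A few compounds are considered here, and "the series" means these few. Any claim that something is new, unique, unknown or untested is made for them only; others in the source may bear on it.

Of the compounds shown here, two sharing one core have been tested so far in an ADME assay on CCRF-HSB-2 cells (Homo sapiens) for cytotoxicity, with a stated time of 7 days; a lower number here means that less compound is tolerated, a higher number that more compound is tolerated. Compound 1 `CN(C)c1nc(N)nc2c1ncn2/C=C1/CC1(CO)CO` gives > 20000 nM, which is a limit of the assay and not a number. Compound 2 `Nc1nc2c(ncn2/C=C2/CC2(CO)CO)c(=O)[nH]1` gives > 20000 nM, which is likewise a limit. Compound 1 therefore stands at the limit of > 20000 nM in this assay, at which 2 of the 2 values shown sit, and no numerical value is yet available for either compound.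

The next compound, compound 3 `Nc1nc(NC2CCCC2)c2ncn(/C=C3/CC3(CO)CO)c2n1`, keeps the shared core but carries cyclopentylamino in place of dimethylamino on an aromatic carbon, next to the ring nitrogen: cyclopentylamino in place of dimethylamino on an aromatic carbon. Among the compounds with values here, no measured step between closely matched compounds is available to gauge what such a change does. In this assay, the estimated a number no higher from compound 1 to compound 3 (the limit leaves the size open) is expected to be no step beyond the usual scatter. This expectation rests on compound 1, whose limit of > 20000 nM is the only reference point for the change. Compound 3 is estimated at 20000 nM, with an expected range from 6000 nM to 50000 nM.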

Compound 3, half-maximal cytotoxic concentration: > 20000 nM
Compound 3 ended at the assay's limit; the forecaster's own chance of this, stated with the estimate: 60%; the middle value lies on the limit itself.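

In this assay compound 3, like compound 1, ends at a limit and not at a number, so the change from compound 1 to compound 3 cannot be read as a step: the limit of > 20000 nM in this assay, at which 3 of the 3 values shown sit.

The compounds shown leave open whether cyclopentylamino in place of dimethylamino changes cytotoxicity at all, and at what concentration any of the three compounds becomes cytotoxic.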